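Turning the single stereocentre of compound 1

The source may report more compounds than this note shows. Statements on the series, on what has been measured and on what is new or still open speak of the compounds shown alone.

Compound 1, with the structure `CCCSc1nc(NC(C)=O)cc(O[C@H](C)c2ccccc2)n1`, is one of three compounds sharing the same core and measured in an assay on CHO cells for displacement of a labelled ligand from adenosine receptor A3 (Homo sapiens), with a stated time of 180 min; on this read-out lower numbers stand for stronger inhibition and higher numbers for weaker inhibition. In this assay compound 1 gives 1.7 nM, the lowest of the three numbers. Compound 2, `CC[C@@H](C)Oc1cc(NC(C)=O)nc(SCc2ccccc2)n1`, gives 1390 nM, and compound 3, `CCC(C)Oc1cc(NC(C)=O)nc(SCc2ccccc2)n1`, gives 195 nM. Compound 4, `CCCSc1nc(NC(C)=O)cc(O[C@@H](C)c2ccccc2)n1`, has not yet been measured; it differs from compound 1 as follows: the two compounds have the same atoms and bonds and differ only in configuration as drawn: 1 of 1 stereo elements differ; a stereocentre at a saturated chain carbon is drawn R in compound 1 and S in compound 4. For the measured compounds named here, only one measured step touches on a change of configuration, and it is an indirect one: a 7.1-fold lower number from compound 2 to compound 3 (0.85 log units; beyond the scatter). That pair tells something because of the fact that one of compounds 2 and 3 is drawn with a defined configuration and the other without, at the place where they differ, but it sits in a different side chain, so its bearing on compound 4 is uncertain. A mirror-image change at a single centre can leave the number nearly unchanged or shift it strongly. The expectation for this assay is therefore a modest move upward, with a wide range, giving a 4.7-fold higher number from compound 1 to compound 4 (0.67 log units; beyond the scatter). Compound 4 is estimated at 8 nM, between 0.8 nM and 150 nM.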

Compound 4, inhibition constant: 0.5 nM
Beside the measured number, compound 4's estimate is 16-fold (1.20 log units) above it; the whole stated range lies above it.
By their numbers in this assay, from the lowest: compound 4; then compound 1; then compound 3; then compound 2.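

Turning the stereocentre at the saturated chain carbon from R to S gives, in this assay, a 3.4-fold lower number from compound 1 to compound 4 (0.53 log units; beyond the scatter). For the compounds shown here, this is the first direct comparison of the two mirror forms at this carbon, and it shows that the configuration here matters only modestly, with both forms giving low numbers. The step can be read as an effect of configuration alone because nothing else changes: the fact that compounds 1 and 4 differ only in the configuration as drawn

The earlier step, a 7.1-fold lower number from compound 2 to compound 3 (0.85 log units; beyond the scatter), set a defined drawing against an undefined one in a different side chain, so it could not offer this R against S reading. From the compounds shown here alone, whether the S form would keep its edge with a cyclohexyl group in place of the phenyl group stays open, as does how the two mirror forms compare at other adenosine receptors.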